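From 3-hydroxypropoxy to 2-carboxyethoxy on a shared core

The compounds below may be only part of what the source reports. "The series", "measured", "known", "first", "only" and "open" are said of these compounds alone.

In a functional assay on a cell-free system (plasma, Oryctolagus cuniculus) for inhibition, with stated times of 5 min, 1 min and 6 min (on this read-out lower numbers stand for stronger inhibition and higher numbers for weaker inhibition), compound 1 (`CCOC(=O)c1c(C)nc(-c2cccc(C#N)c2)n1OC`) gives 9130 nM and compound 2 (`CCOC(=O)c1c(C)nc(-c2cccc(C#N)c2)n1OCCCO`) gives 11400 nM as its reading. Compound 2 therefore stands within the scatter of compound 1, and the two cannot be ranked. Compound 3 (`CCOC(=O)c1c(C)nc(-c2cccc(C#N)c2)n1OCCC(=O)O`) keeps the core of compound 2 and differs only at the end of the chain (carboxy in place of hydroxymethyl on a saturated chain carbon, two bonds along the chain from an oxygen on an aromatic ring), where carboxy stands in place of hydroxymethyl, two bonds along the chain from an oxygen on an aromatic ring. Among the compounds with values here, only one measured step touches this part of the molecule, 2-hydroxyethyl in place of hydrogen, and it amounts to a 1.2-fold higher number from compound 1 to compound 2 (0.10 log units; within the scatter) on this read-out. Neither measured compound carries a carboxy group, so the data give no direction for this change. No step beyond the scatter is expected, though with little evidence behind that expectation, and the estimated step is a 1.1-fold lower number from compound 2 to compound 3 (0.06 log units; within the scatter) in this assay for now. For compound 3 the estimated value is 10000 nM with an expected range from 2500 nM to 40000 nM in this assay when measured.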

Compound 3, half-maximal inhibitory concentration: > 30000 nM
Compound 3: no number, only a limit (the forecaster's own chance of this, stated with the estimate: 15%); middle value at least 3.0-fold (0.47 log units) away from the limit.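

The reading of compound 3 is a limit of the assay and not a number: the limit of > 30000 nM in this assay, at which 1 of the 3 values shown sits. Carboxy in place of hydroxymethyl on a saturated chain carbon, two bonds along the chain from an oxygen on an aromatic ring, is the first change here to pass the scatter, giving an at least 2.6-fold higher number from compound 2 to compound 3 (0.42 log units; beyond the scatter). Carboxymethyl in place of hydrogen on the chain carbon bound to that oxygen likewise gives an at least 3.2-fold higher number from compound 1 to compound 3 (0.51 log units; beyond the scatter), whereas 2-hydroxyethyl at the same carbon gave only a 1.2-fold higher number from compound 1 to compound 2 (0.10 log units; within the scatter), so among these three compounds the group at the end of the chain decides the reading, and a chain as such does not.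

The compounds shown leave open whether this weakening belongs to the free carboxylic acid itself or would also follow a methyl ester or a primary amide at the same chain end. They also leave open how an amine at that end would read, and whether a carboxylic acid on a shorter or longer chain would carry the same penalty.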